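Working notes: trifluoromethyl in place of bromo

The source may report more compounds than this note shows. Statements on the series, on what has been measured and on what is new or still open speak of the compounds shown alone.

In an ADME assay on THP-1 cells (Homo sapiens) for cytotoxicity, read by trypan blue exclusion, with a stated time of 24 h (a lower number here means a stronger inhibitor, a higher number a weaker inhibitor), compound 1 (`N#C[Se]Cc1ccc([N+](=O)[O-])cc1`) gives 16800 nM and compound 2 (`N#C[Se]Cc1ccc(Br)cc1`) gives 28900 nM as its value, so compound 2 stands within the scatter of compound 1. Compound 3 (`N#C[Se]Cc1ccc(C(F)(F)F)cc1`) carries trifluoromethyl in place of bromo on an aromatic carbon and has not yet been measured. Going by the values given here, one measured step bears on this change: a 1.7-fold higher number from compound 1 to compound 2 (0.24 log units; within the scatter) for bromo in place of nitro on an aromatic carbon. A single step is a thin basis, and it does not test trifluoromethyl. Given that step, no change beyond the scatter is expected in this assay and no direction is favoured. The expected step is small (a 1.2-fold lower number from compound 2 to compound 3 (0.08 log units; within the scatter)) and stays within the scatter. For compound 3 the estimated value is 24000 nM with an expected range from 11000 nM to 45000 nM in this assay.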

Compound 3, half-maximal inhibitory concentration: 19800 nM
Compound 3: middle estimate off by 1.2-fold (0.08 log units), on the high side; low and high end bracket the measured number.
By their numbers in this assay, from the lowest: compounds 1, 3 and 2 (each within the scatter of the next).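

Trifluoromethyl in place of bromo gives a 1.5-fold lower number from compound 2 to compound 3 (0.16 log units; within the scatter) in this assay and thus shows that a group of 4 heavy atoms can replace a single bromine at this aromatic carbon without a step beyond the scatter. Trifluoromethyl in place of nitro gives a 1.2-fold higher number from compound 1 to compound 3 (0.07 log units; within the scatter) and so adds a second step within the scatter, leaving no order among the three groups tested at this place in this assay and no sign yet that this position matters for the read-out. No measurement at hand accounts for these small steps.

As far as these compounds go, whether an amine, a carboxylic acid or a longer chain at this place would give a step beyond the scatter stays open. All three compounds share the rest of the core, so what that part contributes to the numbers cannot be read from them.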